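Cyclopropylamino to acetamido on the core of compound 1

The compounds below may be only part of what the source reports. "The series", "measured", "known", "first", "only" and "open" are said of these compounds alone.

Compound 1 `COc1c(NS(=O)(=O)c2ccc(F)cc2)cc(-c2ccc3nc(NC4CC4)sc3n2)cc1C(N)=O`: 35700 nM
Compound 2 `COc1c(NS(=O)(=O)C2CC2)cc(-c2ccc3nc(NC(C)=O)nn3c2)cc1C(N)=O`: 36300 nM
Compound 3 `COc1c(NS(=O)(=O)C2CC2)cc(-c2ccc3nc(NC(=O)C4CC4)sc3c2)cc1C(N)=O`: 14500 nM

Of the compounds shown here, three have been measured in a functional assay on HCT-116 cells (Homo sapiens) for antiproliferative activity, read by MTT assay, with a stated time of 72 h; on this read-out higher numbers stand for weaker inhibition and lower numbers for stronger inhibition. Compound 1 gives 35700 nM in this assay, the second highest of the three numbers. Compound 2, with its own core and an acetamido group, gives 36300 nM, and this lies within the scatter of the value of compound 1, so no order can be read between them. Compound 3 gives 14500 nM, a lower number than that of compound 1 and beyond the scatter. No pair among these three differs in a single place, so no single step between measured compounds can be drawn.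

Compound 4 `COc1c(NS(=O)(=O)c2ccc(F)cc2)cc(-c2ccc3nc(NC(C)=O)sc3n2)cc1C(N)=O` has not been measured. It differs from compound 1 by one change: acetyl in place of cyclopropyl on a nitrogen on an aromatic ring. Nothing in the measured set isolates this exchange. For the measured compounds named here, the only guide is that compound 2, which carries an acetamido group on a different core, sits in the same weak range as compound 1. The step from compound 1 to compound 4 in this assay is therefore expected to be none beyond the scatter, a 1.0-fold lower number from compound 1 to compound 4 (0.01 log units; within the scatter). Compound 4 is expected to give about 35000 nM, estimated between 12000 nM and 100000 nM.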

Compound 4, half-maximal inhibitory concentration: 4250 nM
Beside the measured number, compound 4's estimate is 8.2-fold (0.92 log units) above it; the measured number lies below the stated range.
By their numbers in this assay, from the lowest: compound 4; then compound 3; then compounds 1 and 2 (each within the scatter of the next).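

In this assay, for the compounds shown here, the exchange of cyclopropyl for acetyl on a nitrogen on an aromatic ring gives an 8.4-fold lower number from compound 1 to compound 4 (0.92 log units; beyond the scatter), and this is the first step in the set that isolates a single change. It shows that this place on the core of compound 1 is not indifferent to the group it carries: with all else held the same, replacing a three-membered carbon ring with an acetyl, which has one hydrogen-bond acceptor and no ring, moves the number beyond the scatter, towards stronger inhibition. Nothing measured here accounts for this step.

The compounds shown do not tell whether the step follows from the arrival of the carbonyl or from the loss of the cyclopropyl ring; an ethyl group, a propanoyl group or a bare amine on the same nitrogen would separate these readings. Also open, as far as these compounds go, is whether the same exchange gives a step of similar size on other cores or with a different group on the sulfonamide nitrogen, such as a methyl group.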